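Removing one methoxy group from an ester of two methoxylated aryl units

The source may hold more compounds than are shown below. What is called first, only, known or untested is meant among the compounds shown, and "the series" means these compounds.

Two measured compounds share the same core, each built from a cinnamyl ester of a cinnamic acid, and differ only in how many methoxy groups sit on the acid-side aromatic ring. Compound 1 `COc1cc(OC)c(OC)cc1/C=C/COC(=O)/C=C/c1ccc(OC)c(OC)c1` carries two methoxy groups there, and compound 2 `COc1cc(OC)c(OC)cc1/C=C/COC(=O)/C=C/c1cc(OC)c(OC)c(OC)c1OC` carries four. In a functional assay on the whole organism (strain Kunming) with Mus musculus as the target, with a stated time of 0.5 h, at a dose of 300 mg/kg by the intraperitoneal route (a higher number here means a weaker effect of the compound at the dose given, a lower number a stronger effect), compound 1 gives 100%, and compound 2 gives 100%. Compound 2 therefore stands level with compound 1 at the digits reported, and the two values lie within the scatter of each other, so no order between them can be drawn.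

Compound 3 `COc1cc(OC)c(OC)cc1/C=C/COC(=O)/C=C/c1cc(OC)c(OC)c(OC)c1` has not yet been measured in this assay. It differs from compound 2 in a single spot: hydrogen in place of methoxy on an aromatic carbon. Since the two measured compounds give the same reading whether the ring carries two or four methoxy groups, the step from compound 2 to compound 3 is expected to lie within the scatter, about no change at the digits printed from compound 2 to compound 3 (within the scatter). Compound 3 is accordingly expected to give 100% in this assay, with a range from 90% to 100%.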

Compound 3, a percentage reported as activity, at one dose (the size of the read-out at that dose, not a potency): 100%
Compound 3: the middle estimate sits on the measured number at the digits printed, and the stated range covers the measured number.
By their numbers in this assay, from the lowest: compounds 1, 2 and 3 (each within the scatter of the next).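

In this assay, losing the methoxy group that sits ortho to a large group gives no change at the digits printed from compound 2 to compound 3 (within the scatter), so at this dose hydrogen and methoxy cannot be told apart at this position. Going by these compounds alone, the matching change on the ring of compound 1, methoxy in place of hydrogen on an aromatic carbon, gives no change at the digits printed from compound 1 to compound 3 (within the scatter), so the three compounds now form a series that varies only in the methoxy groups on the acid-side ring, and no step in it separates the readings. The data offer no explanation for this flat result.

On these data alone, what remains open is whether this position responds to anything other than a methoxy group or a hydrogen, such as a hydroxyl group, an amine or a carboxylic acid, since these three compounds only show that swapping between those two leaves the reading in place. As far as these compounds go, it is also open whether changes elsewhere on the shared core, such as on the other methoxylated ring or at the ester link, would move the reading at all.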